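The source may report more compounds than this note shows. Statements on the series, on what has been measured and on what is new or still open speak of the compounds shown alone.

In an in vivo ADME assay on the whole organism for pharmacokinetics, with Rattus norvegicus as the target (a lower number here means that a smaller share of the oral dose reaches the circulation, a higher number that a larger share of the oral dose reaches the circulation), compound 3 `O=C(Nc1cccnc1-c1ccccc1)N1CCN2C(=O)N([C@H]3C[C@@H]3c3ccccc3)C(=O)[C@@H]2C1` gives 31% and lies within the scatter of compound 1 `O=C(Nc1cccnc1-c1ccsc1)N1CCN2C(=O)N([C@H]3C[C@@H]3c3ccccc3)C(=O)[C@@H]2C1` whose 41% sits close by. Compound 2 `CS(=O)(=O)c1cc(Cl)c(NC(=O)N2CCN3C(=O)N([C@H]4C[C@@H]4c4ccccc4)C(=O)[C@@H]3C2)c(Cl)c1` gives 74% and clearly exceeds both. Compound 4 `N#Cc1cccc(-c2ncccc2NC(=O)N2CCN3C(=O)N([C@H]4C[C@@H]4c4ccccc4)C(=O)[C@@H]3C2)c1` differs from compound 3 by a single change, cyano in place of hydrogen on an aromatic carbon, which turns phenyl to 3-cyanophenyl. In full, the change reads cyano in place of hydrogen on an aromatic carbon and leaves the rest of the structure untouched. Within the data shown here, the only measured step at this group is a number 10 percentage points lower from compound 1 to compound 3 (within the scatter) and it comes with phenyl in place of thiophen-3-yl on an aromatic carbon. Among the measured compounds shown here, that step replaces one whole group with another, and no measured compound carries a cyano group, so in this assay no step beyond the scatter is expected, in either direction. The expected step is a number 2 percentage points higher from compound 3 to compound 4 (within the scatter) and it remains an estimate. For compound 4 the estimated value is 33% with an expected range from 15% to 52% on present evidence.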

Compound 4, oral bioavailability: 43%
Compound 4: middle estimate off by 10 percentage points, on the low side; the measured number falls inside the stated range.
By their numbers in this assay, from the lowest: compounds 3, 1 and 4 (each within the scatter of the next, the first and the last beyond it); then compound 2.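

In this assay, this position on the phenyl ring accepts a substituent with a measurable result: cyano in place of hydrogen, meta to a large group, gives a number 12 percentage points higher from compound 3 to compound 4 (beyond the scatter) as a modest step, the first at this position beyond the scatter. The swap of whole groups reads differently, since 3-cyanophenyl in place of thiophen-3-yl gives a number 2 percentage points higher from compound 1 to compound 4 (within the scatter) and leaves the two groups not told apart in this assay. Nothing available explains why the cyano group moves the number.

Going by these compounds, whether the step belongs to the cyano group itself or would follow from other groups at this place stays open, and a methoxy, an amine or a carboxylic acid on the same ring would help to tell. The compounds shown also leave open whether a cyano group on thiophen-3-yl would give a similar step.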